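Methyl on the Amine Nitrogen: From Compound 3 to Compound 4

This account rests on a few compounds, and the source may have more. Where it says the series, first, only, none or still open, it means among the compounds named here.

Of the compounds shown here, three sharing one core have been tested in a functional assay on MCF7 cells (Homo sapiens) for antiproliferative activity; on this read-out higher numbers stand for weaker inhibition and lower numbers for stronger inhibition. Compound 1 `CC(C)=CCc1cc(C(=O)Nc2cc3ccc(OCCCNC(C)C)c(C)c3oc2=O)ccc1O` gives 740 nM. Compound 2 `CC(C)=CCc1cc(C(=O)Nc2cc3ccc(OCCCN(C)C(C)C)c(C)c3oc2=O)ccc1O` gives 1050 nM in this assay; the change from compound 1 to compound 2 is methyl in place of hydrogen on an amine nitrogen, and it made a 1.4-fold higher number from compound 1 to compound 2 (0.15 log units; within the scatter). Compound 3 `CC(C)=CCc1cc(C(=O)Nc2cc3ccc(OCCCNC4CCCCC4)c(C)c3oc2=O)ccc1O` gives 1070 nM in this assay; it differs from compound 1 by cyclohexyl in place of isopropyl on an amine nitrogen, a step of a 1.4-fold higher number from compound 1 to compound 3 (0.16 log units; within the scatter), and the other pair shows a 1.0-fold higher number from compound 2 to compound 3 (0.01 log units; within the scatter).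

Compound 4 `CC(C)=CCc1cc(C(=O)Nc2cc3ccc(OCCCN(C)C4CCCCC4)c(C)c3oc2=O)ccc1O` has not yet been measured. It differs from compound 3 by methyl in place of hydrogen on an amine nitrogen. This is the same kind of change as that from compound 1 to compound 2, though the place is not identical: in compound 1 the other neighbours of the amine nitrogen are saturated chain carbon, saturated chain carbon, whereas in compound 3 they are saturated chain carbon, saturated ring carbon. Because the earlier step was a 1.4-fold higher number from compound 1 to compound 2 (0.15 log units; within the scatter), a step of like size is expected in this assay: a 1.4-fold higher number from compound 3 to compound 4 (0.13 log units; within the scatter). Compound 4 is therefore estimated at 1450 nM, with a range from 700 nM to 3000 nM.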

Compound 4, half-maximal inhibitory concentration: 1080 nM
Beside the measured number, compound 4's estimate is 1.3-fold (0.13 log units) above it; the range from low to high includes it.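

In this assay, methyl in place of hydrogen on the amine nitrogen of the cyclohexylamino compound gave a 1.0-fold higher number from compound 3 to compound 4 (0.00 log units; within the scatter), and this step shows no difference from the one seen with the isopropylamino group: the same change on two cores in this assay, a 1.4-fold higher number (0.15 log units; within the scatter) from compound 1 to compound 2 and a 1.0-fold higher number (0.00 log units; within the scatter) from compound 3 to compound 4, 1.4-fold (0.15 log units) apart, within the scatter of two such steps. Cyclohexyl in place of isopropyl, read with the methyl present, gave a 1.0-fold higher number from compound 2 to compound 4 (0.01 log units; within the scatter), which likewise agrees with the same change read without the methyl: the same change on two cores in this assay, a 1.4-fold higher number (0.16 log units; within the scatter) from compound 1 to compound 3 and a 1.0-fold higher number (0.01 log units; within the scatter) from compound 2 to compound 4, 1.4-fold (0.15 log units) apart, within the scatter of two such steps. Both changes together gave a 1.5-fold higher number from compound 1 to compound 4 (0.16 log units; within the scatter), so these four compounds show that each change can be carried from one core to the other with no detectable difference, but with every step inside the scatter they do not show that either change has a real effect of its own, or that such an effect would add up.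

Going by these compounds, it remains open whether an ethyl group on the amine nitrogen, or a piperidine or morpholine ring in place of this amine, would give a step beyond the scatter. On these data alone, it is also open whether the methyl step would stay this small on a longer chain.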